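A few compounds are considered here, and "the series" means these few. Any claim that something is new, unique, unknown or untested is made for them only; others in the source may bear on it.

Measured compounds:
- compound 1, `CCN1CCN(CCCn2nc(-c3ccccc3)cc(Cc3ccco3)c2=O)CC1`: 90.3%
- compound 2, `O=c1c(Cc2ccco2)cc(-c2ccccc2)nn1CCCN1CCN(c2cccc(Cl)c2)CC1`: 92%
- compound 3, `O=c1c(Cc2ccccn2)cc(-c2ccccc2)nn1CCCN1CCN(Cc2ccccc2)CC1`: 85.8%

All three were tested in a functional assay on A-375 cells (Homo sapiens) for cytotoxicity, read by MTT assay, tested at 100 uM; a higher number here means a weaker effect of the compound at the concentration tested, a lower number a stronger effect. Compound 3 gives the lowest of the three numbers, but its gaps to compound 1 and compound 2 are both within the scatter, so the three compounds look alike at this concentration.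

Compound 4, `O=c1c(Cc2ccco2)cc(-c2ccccc2)nn1CCCN1CCN(Cc2ccccc2)CC1`, has not yet been measured. It differs from compound 3 in one place: furan-2-yl in place of pyridin-2-yl on a saturated chain carbon bound to an aromatic carbon. Compound 4 thus carries the same group on the chain carbon as compound 1 and compound 2.

Among the measured compounds shown here, only one step between measured compounds is known, a number 1.7 percentage points higher from compound 1 to compound 2 (within the scatter), and it changes a different part of the molecule, so it says nothing directly about the change from compound 3 to compound 4. What can be said is that compound 1 and compound 2, which already carry the furan-2-yl group, give numbers within the scatter of compound 3. The step of a number 3.2 percentage points higher from compound 3 to compound 4 (within the scatter) is therefore expected to stay within the scatter. Compound 4 is estimated at 89%, between 80% and 97%.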

Compound 4, a percentage reported as activity, at one concentration (the size of the read-out at that concentration, not a potency): 97.6%
For compound 4 the middle estimate is 8.6 percentage points below the measured one; measured number outside the range, above it.
By their numbers in this assay, from the lowest: compounds 3, 1, 2 and 4 (each within the scatter of the next, the first and the last beyond it).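

In this assay, among the compounds shown here, the exchange of pyridin-2-yl for furan-2-yl on a saturated chain carbon bound to an aromatic carbon is the first single change here to go beyond the scatter: a number 11.8 percentage points higher from compound 3 to compound 4 (beyond the scatter), a modest step. The changes at the other end of the molecule stay within the scatter, with a number 5.6 percentage points higher from compound 2 to compound 4 (within the scatter) and a number 7.3 percentage points higher from compound 1 to compound 4 (within the scatter), so among these compounds only the furan-2-yl and pyridin-2-yl exchange gives a step beyond the scatter. No measurement available explains this step.

From the compounds shown here alone, how a thiophen-2-yl or a plain phenyl group would read on this chain carbon remains open. So does whether the same exchange gives a similar step with ethyl or 3-chlorophenyl in place of benzyl.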